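Swapping the aryl group on sulfur in a quinoxaline diamine series

A few compounds are considered here, and "the series" means these few. Any claim that something is new, unique, unknown or untested is made for them only; others in the source may bear on it.

Compound 1 `Nc1cc(N)c2nc(-c3ccccc3)c(Oc3ccc(Cl)c(Cl)c3)nc2c1`: < 100000 nM
Compound 2 `COc1ccc(Sc2nc3cc(N)cc(N)c3nc2-c2ccccc2)cc1`: < 100000 nM

Of the compounds shown here, two have been measured in a functional assay on NCI-H23 cells (Homo sapiens) for inhibition, read by sulforhodamine B assay, with a stated time of 48 h; a lower number here means that less compound is tolerated, a higher number that more compound is tolerated. Compound 1 gives < 100000 nM in this assay, which is a limit of the assay and not a number. Compound 2 likewise gives only a limit, < 100000 nM. The step that the two limits leave unreadable from compound 1 to compound 2 therefore cannot be read, since (the limit of < 100000 nM in this assay, at which 2 of the 2 values shown sit). Compound 2 thus stands only at a limit, with no number of its own.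

Compound 3 `Nc1cc(N)c2nc(-c3ccccc3)c(Sc3ccc(Cl)c(Cl)c3)nc2c1` differs from compound 2 by 3,4-dichlorophenyl in place of 4-methoxyphenyl on a sulfur. Within the data shown here, the aryl group entering is the one that compound 1 carries on oxygen, and compound 1 sits at the same limit as compound 2. Nothing measured shows a step of readable size, so no change beyond the scatter is expected: the expected step that the limit leaves unreadable from compound 2 to compound 3 is small. Compound 3 is estimated at 40000 nM in this assay, in the range 8000 nM to 100000 nM.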

Compound 3, concentration lethal to 50% of the cells: 95500 nM
Compound 3: middle estimate off by 2.4-fold (0.38 log units), on the low side, within the range that was stated.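

Compound 3 has a number of its own, but its steps from compound 1 and compound 2 cannot be read, because both of those compounds stand only at a limit: the limit of < 100000 nM in this assay, at which 2 of the 3 values shown sit. The compounds shown leave open whether changing the aryl group on sulfur, or oxygen to sulfur, alters the read-out at all.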